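Hexylsulfanyl for isobutylamino on the shared core

A few compounds are considered here, and "the series" means these few. Any claim that something is new, unique, unknown or untested is made for them only; others in the source may bear on it.

- Compound 1 `C=CCOc1nc(N)nc2c1ncn2/C=C1/CC1(CO)CO`: > 20000 nM, a limit
- Compound 2 `CN(C)c1nc(N)nc2c1ncn2/C=C1/CC1(CO)CO`: > 20000 nM, a limit
- Compound 3 `CC(C)CNc1nc(N)nc2c1ncn2/C=C1/CC1(CO)CO`: > 20000 nM, a limit
- Compound 4 `CCCCCCSc1nc(N)nc2c1ncn2/C=C1/CC1(CO)CO`: not yet measured

All three measured compounds were read in an ADME assay on CCRF-HSB-2 cells (Homo sapiens) for cytotoxicity, with a stated time of 7 days (a higher number here means that more compound is tolerated, a lower number that less compound is tolerated), and the limit of > 20000 nM in this assay, at which 3 of the 3 values shown sit, shows that none of them has left the limit. Compound 3 stands at > 20000 nM, which is a limit and not a number. Its rank within the series therefore cannot be read.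

The next change is hexylsulfanyl in place of isobutylamino on an aromatic carbon.

Going by the values given here, three measured steps bear on this change, all at the same place on the shared core: a step that the two limits leave unreadable from compound 1 to compound 2, a step that the two limits leave unreadable from compound 1 to compound 3 and a step that the two limits leave unreadable from compound 2 to compound 3. Among the compounds with values here, none has a readable size, and no compound goes against the run of limits. None of the three carries hexylsulfanyl, so the series offers no measured guide to this group.

No step beyond the scatter can be forecast in either direction, and another limit reading is the likeliest outcome. The expected change is a number no higher from compound 3 to compound 4 (the limit leaves the size open), an estimate resting on limits alone. For compound 4 the estimated half-maximal cytotoxic concentration is 20000 nM, with an expected range of 7000 nM to 60000 nM.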

Compound 4, half-maximal cytotoxic concentration: 60000 nM
Estimate against measurement, compound 4: 3.0-fold (0.48 log units) below; the measured number falls inside the stated range.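

No step from compound 1, compound 2 or compound 3 to compound 4 can be read, since each of those three compounds stands at a limit and not a number: the limit of > 20000 nM in this assay, at which 3 of the 4 values shown sit.

Left open is how compound 1, compound 2 and compound 3 truly rank in this assay, and where each stands relative to compound 4 at 60000 nM.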